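The compounds below may be only part of what the source reports. "The series", "measured", "known", "first", "only" and "open" are said of these compounds alone.

Working notes on the series in a functional assay on MDA-MB-231 cells (Homo sapiens) for antiproliferative activity, read by CCK-8 assay, with a stated time of 72 h; a higher number here means a weaker inhibitor, a lower number a stronger inhibitor.

Among the compounds with values here, compound 1 `COc1ccc(C(=O)Nc2cccc(-c3oc4cc(-c5ccc(F)cc5)ccc4c(=O)c3O)c2)cc1` gives 16500 nM in this assay, the highest number of the two measured so far. Within the data shown here, its nearest neighbour is compound 2 `COc1ccccc1C(=O)Nc1cccc(-c2oc3cc(-c4ccc(F)cc4)ccc3c(=O)c2O)c1`, which gives 5110 nM in this assay; the single measured step is a 3.2-fold lower number from compound 1 to compound 2 (0.51 log units; beyond the scatter), a change in where the methoxy sits on the aryl ring attached to the carbonyl carbon.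

Compound 3 `Cc1cc(C(=O)Nc2cccc(-c3oc4cc(-c5ccc(F)cc5)ccc4c(=O)c3O)c2)ccc1F` is not yet measured. Against compound 1 the change is 4-fluoro-3-methylphenyl in place of 4-methoxyphenyl on a carbonyl carbon. Among the measured compounds shown here, no measured step covers a replacement of this kind: the step from compound 1 to compound 2 moves a substituent around the same ring and is therefore only a loose guide. It shows that changes on this ring can move the number by a modest amount, but gives no direction for exchanging the methoxy for fluorine and methyl together.

For compound 3 the number in this assay is therefore expected close to compound 1, with the step of a 1.5-fold lower number from compound 1 to compound 3 (0.18 log units; within the scatter) taken as uncertain in direction. The estimate for compound 3 is 11000 nM, within a range from 3500 nM to 35000 nM.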

Compound 3, half-maximal inhibitory concentration: 7440 nM
The estimate for compound 3 lay 1.5-fold (0.17 log units) above the measured number; low and high end bracket the measured number.
By their numbers in this assay, from the lowest: compounds 2 and 3 (each within the scatter of the next); then compound 1.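

In this assay, within the data shown here, the exchange of 4-methoxyphenyl for 4-fluoro-3-methylphenyl on the carbonyl carbon gives a 2.2-fold lower number from compound 1 to compound 3 (0.35 log units; beyond the scatter) and so shows that the number at this position can also fall when the methoxy group is removed altogether, with the entering group counting no hydrogen-bond acceptor against the one in the group that leaves. The comparison with the other methoxy isomer gives a 1.5-fold higher number from compound 2 to compound 3 (0.16 log units; within the scatter) and so leaves two quite different replacements of 4-methoxyphenyl indistinguishable in this assay, while compound 1 stays the weakest of the three by steps beyond the scatter. Nothing measured here accounts for either step.

The compounds shown leave open whether the fluorine or the methyl of 4-fluoro-3-methylphenyl carries the step from compound 1, as the two enter together and neither is seen alone on this ring. From the compounds shown here alone, it also remains open how an amine, a carboxylic acid or a longer alkyl chain on this ring would move the number, and whether any such group would reach clearly lower numbers than those of compound 2 and compound 3.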